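The compounds below may be only part of what the source reports. "The series", "measured", "known", "first", "only" and "open" are said of these compounds alone.

Compound 1 `CCC1=C(O)c2c(oc(-c3ccc(COC)cc3)cc2=O)C(CC)(CC)C1=O`: 3.4 uM
Compound 2 `CCC1=C(O)c2c(oc(-c3cccc(F)c3)cc2=O)C(CC)(CC)C1=O`: 3.09 uM
Compound 3 `CCC1=C(O)c2c(oc(-c3ccccc3C)cc2=O)C(CC)(CC)C1=O`: 2.41 uM

These values come from a functional assay on KBVIN cells (Homo sapiens) for antiproliferative activity, read by sulforhodamine B assay, with a stated time of 3 days; on this read-out higher numbers stand for an effect only at larger amounts of compound and lower numbers for an effect already at smaller amounts. Compound 3 cannot be told apart from the other two, since a 1.4-fold lower number from compound 1 to compound 3 (0.15 log units; within the scatter) and a 1.3-fold lower number from compound 2 to compound 3 (0.11 log units; within the scatter) are both within the scatter. Compound 4 `CCC1=C(O)c2c(oc(-c3ccc(C)c(Cl)c3)cc2=O)C(CC)(CC)C1=O` keeps the shared core but has 3-chloro-4-methylphenyl in place of 2-methylphenyl, on the aromatic carbon next to the ring oxygen: 3-chloro-4-methylphenyl in place of 2-methylphenyl on an aromatic carbon. The three measured steps change the group at this same place, and a 1.1-fold lower number from compound 1 to compound 2 (0.04 log units; within the scatter) is also within the scatter. Among the compounds with values here, no measured compound carries chlorine, so this evidence is indirect, and no step beyond the scatter is expected in this assay. The expected change is a 1.2-fold higher number from compound 3 to compound 4 (0.07 log units; within the scatter). For compound 4, the estimate is 2.8 uM, with an expected range of 1.3 uM to 6 uM.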

Compound 4, concentration for half-maximal effect: 2.15 uM
Compound 4: middle estimate off by 1.3-fold (0.11 log units), on the high side, within the range that was stated.
By their numbers in this assay, from the lowest: compounds 4, 3, 2 and 1 (each within the scatter of the next).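

Within the data shown here, at the aromatic carbon next to the ring oxygen, 3-chloro-4-methylphenyl, the first group here that carries chlorine, cannot be told apart from the other three groups in this assay. All three new steps lie within the scatter: a 1.1-fold lower number from compound 3 to compound 4 (0.05 log units; within the scatter), a 1.4-fold lower number from compound 2 to compound 4 (0.16 log units; within the scatter) and a 1.6-fold lower number from compound 1 to compound 4 (0.20 log units; within the scatter). Nothing measured here offers an explanation for this flat picture. Still open, on these data alone, is whether a group of another kind at this place, such as a phenyl carrying an amine or a carboxylic acid, would give a step beyond the scatter.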